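The compounds below may be only part of what the source reports. "The series", "measured", "known", "first", "only" and "open" are said of these compounds alone.

Working notes on the series. In an ADME assay on Vero cells (Chlorocebus sabaeus) for cytotoxicity (a higher number here means that more compound is tolerated, a lower number that less compound is tolerated), compound 1 `CCCCCCCCCCSc1ncnc2c1ncn2Cc1ccccc1` has the entry "not determined" (no result reported), so it offers no basis for comparison. In this assay compound 2 `CCCCCCCCCCSc1ncnc2c1ncn2CC(=O)OCC` gives > 62.5 ug/mL, which is a limit of the assay and not a number. Among the measured compounds shown here, the only evidence on hand is therefore (the limit of > 62.5 ug/mL in this assay, at which 1 of the 2 values shown sits).

Compound 3 `CCCCCCCCCCCCSc1ncnc2c1ncn2CC(=O)OCC` differs from compound 2 by one change in the chain on sulfur: ethyl in place of hydrogen on a saturated chain carbon, ten or more bonds along the chain from a sulfur. For the measured compounds named here, no measured step gives the size of such a change. The expectation rests only on compound 2, whose limit is > 62.5 ug/mL. Expected is an at least 1.0-fold lower number from compound 2 to compound 3 (0.01 log units; that floor lies within the scatter), with no shift beyond the usual scatter in either direction. For compound 3 the estimated value is 60 ug/mL, with an expected range of 25 ug/mL to 130 ug/mL.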

Compound 3, half-maximal cytotoxic concentration: > 10 ug/mL
Compound 3 gave a limit, no number; the forecaster's own chance of this, stated with the estimate: 60%; the middle value does not contradict the limit.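

In this assay compound 3 gives > 10 ug/mL, which is a limit of the assay and not a number. Compound 2 also stands only as a limit, so no step can be read between compound 2 and compound 3. As far as these compounds go, whether the added ethyl changes the tolerated concentration at all remains open.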